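Replacing the hydroxypyrrolidine tail of a stilbene ether

The source may hold more compounds than are shown below. What is called first, only, known or untested is meant among the compounds shown, and "the series" means these compounds.

Compound 1 `COc1ccc(/C=C\c2cc(OC)c(OC)c(OC)c2)cc1OCc1ccc(CN2CCCC[C@H]2C(=O)O)cc1` — > 10000 nM in a functional assay on B16-F10 cells (Mus musculus) for antiproliferative activity, read by CCK-8 assay, with a stated time of 48 h (on this read-out higher numbers stand for weaker inhibition and lower numbers for stronger inhibition), a limit
Compound 2 `COc1ccc(/C=C\c2cc(OC)c(OC)c(OC)c2)cc1OCc1ccc(CN2CCCCC2C(=O)O)cc1` — > 10000 nM in this assay, a limit
Compound 3 `COc1ccc(/C=C\c2cc(OC)c(OC)c(OC)c2)cc1OCc1ccc(CN2CC[C@@H](O)C2)cc1` — > 10000 nM in this assay, a limit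

Compound 3 stands only at a limit in this assay, as do the two other compounds shown. The step that the two limits leave unreadable from compound 1 to compound 2 cannot be read, since the limit of > 10000 nM in this assay, at which 3 of the 3 values shown sit, and the fact that one of compounds 1 and 2 is drawn with a defined configuration and the other without, at the place where they differ leave no number on either side. Likewise a step that the two limits leave unreadable from compound 1 to compound 3 and a step that the two limits leave unreadable from compound 2 to compound 3 stay unreadable.

Compound 4 `COc1ccc(/C=C\c2cc(OC)c(OC)c(OC)c2)cc1OCc1ccc(CN2CCCCC2C(=O)NCCN)cc1` differs from compound 3 in one place: 2-((2-aminoethyl)carbamoyl)piperidin-1-yl in place of 3-hydroxypyrrolidin-1-yl on a saturated chain carbon bound to an aromatic carbon. Among the measured compounds shown here, no measured step covers this change; the only steps that touch the same position, from compounds 1 and 2 to compound 3, give no size. The shared core has shown no number at all here, so the expectation for compound 4 rests on little. The step of an at least 1.6-fold lower number from compound 3 to compound 4 (0.22 log units; that floor lies within the scatter) is expected to be modest, if any. Compound 4 is therefore estimated at 6000 nM, with a range from 400 nM to 30000 nM, and a limit remains a likely outcome.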

Compound 4, half-maximal inhibitory concentration: 4600 nM
Beside the measured number, compound 4's estimate is 1.3-fold (0.12 log units) above it; measured number inside the range.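

In this assay, compound 4 gives the only number among the compounds shown, so the saturated chain carbon bound to an aromatic carbon now shows a direction: with 2-((2-aminoethyl)carbamoyl)piperidin-1-yl in place of 3-hydroxypyrrolidin-1-yl, the result is an at least 2.1-fold lower number from compound 3 to compound 4 (0.33 log units; beyond the scatter). Placing (2-aminoethyl)amino in place of hydroxy on the carbonyl carbon gives an at least 2.1-fold lower number from compound 2 to compound 4 (0.33 log units; beyond the scatter), and the comparison with the compound drawn with a defined configuration gives an at least 2.1-fold lower number from compound 1 to compound 4 (0.33 log units; beyond the scatter). These sizes are floors, and the steps among compound 1, compound 2 and compound 3 still cannot be read, because their values stop at a limit: the limit of > 10000 nM in this assay, at which 3 of the 4 values shown sit.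

The compounds shown leave open whether a plain carboxamide, a methylamide or a longer aminoalkyl chain on that carbonyl carbon would match compound 4. They also leave open whether a defined configuration at the saturated ring carbon of compound 4 would change its number.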